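This account rests on a few compounds, and the source may have more. Where it says the series, first, only, none or still open, it means among the compounds named here.

Working notes on the sulfonamide series in a functional assay on BXPC-3 cells (Homo sapiens) for inhibition, read by MTT assay, with a stated time of 72 h; on this read-out higher numbers stand for weaker inhibition of growth and lower numbers for stronger inhibition of growth.

Three compounds carry the shared core of compound 1 `O=S(=O)(NCCCNCc1ccc(Cl)c(C(F)(F)F)c1)c1cc(C(F)(F)F)cc(C(F)(F)F)c1` with different aryl groups on the saturated chain carbon bound to the amine nitrogen. In this assay compound 1 gives 7800 nM, the highest number of the three. Compound 2 `O=S(=O)(NCCCNCc1cccc2ccccc12)c1cc(C(F)(F)F)cc(C(F)(F)F)c1` gives 2700 nM, and compound 3 `COc1cccc(CNCCCNS(=O)(=O)c2cc(C(F)(F)F)cc(C(F)(F)F)c2)c1` gives 1700 nM. Both changes away from the 4-chloro-3-(trifluoromethyl)phenyl group lower the number beyond the scatter: a 2.9-fold lower number from compound 1 to compound 2 (0.46 log units; beyond the scatter) and a 4.6-fold lower number from compound 1 to compound 3 (0.66 log units; beyond the scatter). Between compound 2 and compound 3 the step is a 1.6-fold lower number from compound 2 to compound 3 (0.20 log units; within the scatter), so these two cannot be ordered.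

Compound 4 `O=S(=O)(NCCCNCc1ccc(Cl)cc1)c1cc(C(F)(F)F)cc(C(F)(F)F)c1` differs from compound 1 as follows: hydrogen in place of trifluoromethyl on an aromatic carbon. For the measured compounds named here, no measured step removes a single substituent from an otherwise kept aryl group; the two steps from compound 1 exchange the whole ring. They show only that the 4-chloro-3-(trifluoromethyl)phenyl group gives the weakest inhibition of growth so far. A partial change of that group is expected to move the number less than either full exchange, and its direction is uncertain, so a step within the scatter or a modest lowering is expected: a 1.6-fold lower number from compound 1 to compound 4 (0.19 log units; within the scatter).

For compound 4 the estimate is 5000 nM, expected to fall between 2000 nM and 15000 nM.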

Compound 4, concentration for 50% growth inhibition: 1600 nM
Compound 4: middle estimate off by 3.1-fold (0.49 log units), on the high side; measured number below the stated range.
By their numbers in this assay, from the lowest: compounds 4, 3 and 2 (each within the scatter of the next); then compound 1.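

Removing only the trifluoromethyl and keeping the chloro group gives a step in this assay beyond the scatter, a 4.9-fold lower number from compound 1 to compound 4 (0.69 log units; beyond the scatter), so a single substituent at this place on the ring, ortho to a chloro group, is enough to separate compound 1 from compound 4, and the whole ring need not be exchanged. Compound 4 also joins the other two analogues, with a 1.1-fold lower number from compound 3 to compound 4 (0.03 log units; within the scatter) and a 1.7-fold lower number from compound 2 to compound 4 (0.23 log units; within the scatter), so the 4-chlorophenyl, 3-methoxyphenyl and naphthalen-1-yl compounds cannot be ordered, and compound 1 alone stands apart as the weakest of the four. No measurement shown here explains why the loss of this one group goes with the lower number.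

The compounds shown leave open whether the step belongs to trifluoromethyl in particular or would recur with a methyl, a fluoro or a nitrile at the same place, and whether trifluoromethyl on a ring without the chloro group would give a number like that of compound 1. They also leave open how this aryl comparison would hold on a longer chain between the two nitrogens.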